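The source may hold more compounds than are shown below. What is called first, only, known or untested is meant among the compounds shown, and "the series" means these compounds.

Compound 2, `C=C(C)CCC[C@]1(C)C2=CCC[C@](C)(C[C@H](O)c3ccoc3)[C@H]2CC[C@H]1C`, is the starting point of this step. In a functional assay on HL-60 cells (Homo sapiens) for antiproliferative activity, read by XTT assay, with a stated time of 72 h (on this read-out higher numbers stand for weaker inhibition and lower numbers for stronger inhibition), compound 2 gives 31200 nM, the lowest of the two numbers reported. Compound 3, `CC(C)=CCC[C@]1(C)C2=CCC[C@](C)(CC(=O)c3ccoc3)[C@H]2CC[C@H]1C`, sits nearest to it: in this assay compound 3 gives 57800 nM, a gap that lies within the scatter, so the two cannot be told apart. Compound 1, `C=C(C)CCC[C@]1(C)C2=CCC[C@](C)(CC(=O)c3ccoc3)[C@H]2CC[C@H]1C`, is the shared parent of both. In this assay compound 1 reaches only a limit, > 100000 nM, and no number is known for it. From that limit, two steps are known: an at least 3.2-fold lower number from compound 1 to compound 2 (0.50 log units; beyond the scatter), and an at least 1.7-fold lower number from compound 1 to compound 3 (0.23 log units; that floor lies within the scatter).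

Compound 4, `C=C(C)CCC[C@]1(C)C2=CCC[C@](C)(C[C@H](O)C3=CC(=O)OC3O)[C@H]2CC[C@H]1C`, differs from compound 2 in one place: a group of 7 heavy atoms (4 carbon, 3 oxygen; one five-membered non-aromatic ring with 1 hetero atom) in place of a group of 5 heavy atoms (4 carbon, 1 oxygen; one five-membered aromatic ring with 1 hetero atom), on a saturated chain carbon bound to an oxygen on a saturated carbon and a saturated chain carbon. Neither measured step bears directly on this change. The step from compound 1 to compound 2 alters the carbon that carries the ring, not the ring itself, and the step from compound 1 to compound 3 alters the distant side chain. The ring exchange has no precedent among these compounds, so its direction cannot be read from them. Compound 4 is therefore expected to stay near compound 2, with a wide range: the expected step is a 1.0-fold lower number from compound 2 to compound 4 (0.02 log units; within the scatter). In this assay compound 4 is estimated at 30000 nM, between 6000 nM and 150000 nM.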

Compound 4, half-maximal inhibitory concentration: 3000 nM
Beside the measured number, compound 4's estimate is 10-fold (1.00 log units) above it; the measured number lies below the stated range.
By their numbers in this assay, from the lowest: compound 4; then compounds 2 and 3 (each within the scatter of the next). At a limit, above all of these: compound 1.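

In this assay, putting the non-aromatic five-membered ring group in place of furan-3-yl produces a large step (a 10-fold lower number from compound 2 to compound 4 (1.02 log units; beyond the scatter)), on a saturated chain carbon bound to an oxygen on a saturated carbon and a saturated chain carbon. Going by these compounds alone, the earlier steps left the ring unchanged, so this is the first sign that the ring itself is a place where the number can move this far, and the wider step (an at least 33-fold lower number from compound 1 to compound 4 (1.52 log units; beyond the scatter)) starts from a limit rather than a number and joins the ring exchange with the change on the carbon that carries the ring. Nothing among the data shown accounts for the size of this step.

The compounds shown leave open whether the step needs the whole entering group or whether a simpler group on the same carbon, such as a carboxylic acid or an amine, would give a similar number. They also leave open whether the entering group would give the same step when combined with the 2-methylprop-1-en-1-yl chain of compound 3 or with the carbonyl of compound 1.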